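The compounds below may be only part of what the source reports. "The series", "measured", "known", "first", "only" and "open" are said of these compounds alone.

Compound 2 `Cn1nc(-c2ccc(Cl)cc2)n(C)c1=S` is the starting point. In a functional assay on the whole organism with Mus musculus as the target (on this read-out lower numbers stand for an effect already at smaller amounts and higher numbers for an effect only at larger amounts of compound), compound 2 gives 1.34 mg/kg, the higher of the two plain numbers available. Compound 1 `Cn1nc(-c2ccccc2F)n(C)c1=S` gives 0.74 mg/kg in this assay, a gap within the scatter, so the two cannot be ordered. Compound 3 `CCCn1c(-c2ccc(Cl)cc2)nn(C)c1=S` reaches only a limit of the assay in this assay, > 12.5 mg/kg. Among the compounds with values here, the single measured step, an at least 9.3-fold higher number from compound 2 to compound 3 (0.96 log units; beyond the scatter), concerns the chain on the ring nitrogen and is known only as a lower bound since compound 3 sits at the limit of > 12.5 mg/kg in this assay, at which 1 of the 3 values shown sits.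

Compound 4 `Cn1nc(-c2ccc(F)cc2)n(C)c1=S` differs from compound 2 in one place: fluoro in place of chloro on an aromatic carbon. Within the data shown here, no measured step touches the halogen on this ring; the step of an at least 9.3-fold higher number from compound 2 to compound 3 (0.96 log units; beyond the scatter) changes a different part of the molecule and says nothing about it. Compound 1 also carries fluoro, but at a different place, so it gives no single-step comparison. With nothing pointing either way, the expected step is a 1.1-fold lower number from compound 2 to compound 4 (0.05 log units; within the scatter), within the scatter. Compound 4 is therefore estimated at 1.2 mg/kg in this assay, between 0.5 mg/kg and 3 mg/kg.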

Compound 4, dose for half-maximal effect: 0.61 mg/kg
Compound 4: middle estimate off by 2.0-fold (0.29 log units), on the high side, and the stated range covers the measured number.
By their numbers in this assay, from the lowest: compounds 4, 1 and 2 (each within the scatter of the next, the first and the last beyond it). At a limit, above all of these: compound 3.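

In this assay, the halogen on the aromatic ring now has a measured effect of its own: at this place, para to a group of 8 heavy atoms, putting fluoro in place of chloro gives a 2.2-fold lower number from compound 2 to compound 4 (0.34 log units; beyond the scatter). Within the data shown here, this modest step is the first to show that a change on this ring can go beyond the scatter, and it moves towards an effect at smaller amounts, whereas the earlier step on the ring nitrogen, an at least 9.3-fold higher number from compound 2 to compound 3 (0.96 log units; beyond the scatter), moves the other way. Nothing shown here gives a reason for the halogen step.

As far as these compounds go, what a methoxy group, a trifluoromethyl group or an amine would do at this same place stays open. Also open, from the compounds shown here alone, is how an ethyl chain on the ring nitrogen would behave when paired with fluoro on the ring.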